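The compounds below may be only part of what the source reports. "The series", "measured", "known", "first", "only" and "open" are said of these compounds alone.

Measured so far:
- compound 1, `C#CCSc1nc(Nc2ccc(Cl)cc2)c(C#N)c(-c2ccccc2)n1`: 19800 nM
- compound 2, `N#Cc1c(Nc2ccc(Cl)cc2)nc(SCc2cn(Cc3ccccc3Cl)nn2)nc1-c1ccccc1`: 1590 nM
- compound 3, `N#Cc1c(Nc2ccccc2F)nc(SCc2cn(Cc3ccc(Cl)cc3)nn2)nc1-c1ccccc1`: > 64000 nM

Of the compounds shown here, three sharing one core have been tested in a functional assay on B16-F10 cells (Mus musculus) for inhibition, read by MTT assay, with a stated time of 72 h; a higher number here means a weaker inhibitor, a lower number a stronger inhibitor. Compound 1 gives 19800 nM in this assay. Compound 2 gives 1590 nM, the lower of the two numbers reported, and its gap to compound 1 is wider than the usual scatter of repeated measurements. For compound 3 this assay reports only a limit, > 64000 nM, so no number is known for it.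

Compound 4, `Cc1ccc(Nc2nc(SCc3cn(Cc4ccccc4Cl)nn3)nc(-c3ccccc3)c2C#N)cc1`, has not yet been measured. It differs from compound 2 in a single place: methyl in place of chloro on an aromatic carbon. Among the measured compounds there is no pair that differs in exactly one place, so the size of a step of this kind cannot be read from them. Swapping one small group for another of the same size on an outer ring is expected to move the number only modestly, and the direction is open; a small loss is assumed here. Compound 4 is expected to give about 3000 nM in this assay, likely between 800 nM and 15000 nM. That corresponds to an estimated step of a 1.9-fold higher number from compound 2 to compound 4 (0.28 log units; within the scatter).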

Compound 4, half-maximal inhibitory concentration: 3390 nM
For compound 4 the middle estimate is 1.1-fold (0.05 log units) below the measured one; measured number inside the range.
By their numbers in this assay, from the lowest: compound 2; then compound 4; then compound 1. At a limit, above all of these: compound 3.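

In this assay, methyl in place of chloro on an aromatic carbon, para to a large group, gives a 2.1-fold higher number from compound 2 to compound 4 (0.33 log units; beyond the scatter) and so supplies the first measured size for any single change in this series. The step is modest, which shows that this place on the outer ring accepts either of these two small groups without the activity disappearing, while the 4-chlorophenyl form holds the lower number of this pair. Nothing measured among these compounds bears on what lies behind this step, so it stands as a plain observation from a single pair.

This one pair says nothing about whether the same swap would act alike on a different compound of the series, and all other steps among the compounds shown cannot be read, as those compounds differ in more than one place. Going by these compounds, it also remains open how the number would respond at this same place to a methoxy group, an amine, a carboxylic acid or a longer chain, or to moving the methyl elsewhere on the ring.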